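A few compounds are considered here, and "the series" means these few. Any claim that something is new, unique, unknown or untested is made for them only; others in the source may bear on it.

Measured compounds:
- compound 1, `C[C@@H]1CN(CCCN(C(=O)Nc2cc(Cl)nc(Cl)c2)[C@@H]2CC[C@]3(c4cnc(CN)s4)CC23)[C@@H](C)CN1`: in a functional assay for antagonist activity at melanin-concentrating hormone receptor 1 (Homo sapiens) (on this read-out lower numbers stand for stronger inhibition and higher numbers for weaker inhibition), compound 1 gives 13.1 nM
- compound 2, `NCc1ncc([C@]23CC[C@@H](N(CCCN4CC5CC4CN5)C(=O)Nc4ccc(F)c(C(F)(F)F)c4)C2C3)s1`: in this assay compound 2 gives 73 nM
- compound 3, `C[C@@H]1CN(CCCN(C(=O)Nc2cc(Cl)nc(Cl)c2)[C@H]2CC[C@]3(c4cnc(CN)s4)C[C@H]23)[C@@H](C)CN1`: in this assay compound 3 gives 6.1 nM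

Compound 3 stands at the lowest number of the three. Compound 1 is nearest to it, and compound 2 is the furthest, its number being well above that of compound 3.

Compound 4, `C[C@@H]1CN[C@@H](C)CN1CCCN(C(=O)Nc1cc(Cl)nc(Cl)c1)[C@H]1CC[C@]2(c3cnc(CN)s3)C[C@H]12`, keeps every atom and bond of compound 3 and changes only configuration at the shared core: the two compounds have the same atoms and bonds and differ only in configuration as drawn: 2 of 5 stereo elements differ; a stereocentre at a saturated ring carbon is drawn S in compound 3 and R in compound 4; a stereocentre at a saturated ring carbon is drawn R in compound 3 and S in compound 4. Among the measured compounds shown here, only one measured step touches configuration at that core, a 2.1-fold lower number from compound 1 to compound 3 (0.33 log units; beyond the scatter), and that comparison is not a clean inversion, since it rests on (the fact that one of compounds 1 and 3 is drawn with a defined configuration and the other without, at the place where they differ). For the measured compounds named here, it does show that the drawn arrangement at these saturated ring carbons moves the number, by a modest amount, and no other step is available.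

Inverting both defined centres of the core is therefore expected to move the number upward rather than downward, with a size comparable to the one step seen. Compound 4 is expected to give 20 nM, within 6 nM to 70 nM. For compound 4 this means an expected step of a 3.3-fold higher number from compound 3 to compound 4 (0.52 log units; beyond the scatter).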

Compound 4, inhibition constant: 4 nM
Estimate against measurement, compound 4: 5.0-fold (0.70 log units) above, outside the stated range (below it).
By their numbers in this assay, from the lowest: compounds 4 and 3 (each within the scatter of the next); then compound 1; then compound 2.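

In this assay, among the compounds shown here, this pair is the first comparison between two fully defined stereoisomers, and it gives a 1.5-fold lower number from compound 3 to compound 4 (0.18 log units; within the scatter), the change being confined to configuration: the fact that compounds 3 and 4 differ only in the configuration as drawn. Inverting both of these saturated ring carbons together therefore produces no change beyond the scatter, so the pair does not show the sensitivity to configuration that a 2.1-fold lower number from compound 1 to compound 3 (0.33 log units; beyond the scatter) alone might have suggested. The larger difference, a 3.3-fold lower number from compound 1 to compound 4 (0.52 log units; beyond the scatter), cannot be assigned to any single centre, as four stereo elements differ and one of them has no configuration drawn in compound 1: the fact that one of compounds 1 and 4 is drawn with a defined configuration and the other without, at the place where they differ.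

The compounds shown leave open how each of the two inverted centres acts alone, as the two changes appear only together and could offset each other on this read-out. They also leave open whether the tolerance seen between compound 3 and compound 4 would hold with an ethyl group in place of each methyl group on the same ring, or with a hydroxymethyl group there.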